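This account rests on a few compounds, and the source may have more. Where it says the series, first, only, none or still open, it means among the compounds named here.

Compound 1, `CN1CCC(c2ccc3c(c2)oc(=O)n3C(=O)NCCCCc2ccc(F)cc2)CC1`, gives 0.5 h in an ADME assay on microsomes from liver (Mus musculus) for metabolic stability, read by LC-MS, using NADPH, with stated times of 15 min and 60 min, tested at 4.6 uM; on this read-out higher numbers stand for a longer-lived compound and lower numbers for a shorter-lived compound.
Compound 2, `CN1CCC(c2ccc3c(c2)oc(=O)n3C(=O)NCCCCc2ccccc2)CC1=O`, gives 0.583 h in this assay.

Of the compounds shown here, two have been measured so far. Compound 2 sits closest to compound 1, and the two numbers lie within the usual scatter of repeated measurements, so neither can be called longer- or shorter-lived than the other on these data; in this assay compound 2 gives 0.583 h, while compound 1 gives 0.5 h. The pair differs in more than one place, so nothing can be read from it about any single change.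

Compound 3, `CCN1CCC(c2ccc3c(c2)oc(=O)n3C(=O)NCCCCc2ccccc2)CC1`, has not yet been measured. Relative to compound 2 the change is 1-ethylpiperidin-4-yl in place of 1-methyl-2-oxopiperidin-4-yl on an aromatic carbon. For the measured compounds named here, no measured pair shows this change on its own, so there is no step from which its size can be taken. Given that both measured compounds fall within the scatter of each other, the step from compound 2 to compound 3 is expected to be small, a 1.3-fold lower number from compound 2 to compound 3 (0.11 log units; within the scatter), with no direction beyond the scatter claimed. Compound 3 is therefore expected to give about 0.45 h in this assay, within a range of 0.2 h to 1 h.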

Compound 3, half-life: 1 h
Compound 3: middle estimate off by 2.2-fold (0.35 log units), on the low side; the measured number falls inside the stated range.
By their numbers in this assay, from the lowest: compounds 1, 2 and 3 (each within the scatter of the next).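

For the compounds shown here, the swap of 1-methyl-2-oxopiperidin-4-yl for 1-ethylpiperidin-4-yl on an aromatic carbon gives the first reading of a change in one place, as the earlier pair differed in more than one. In this assay, this change gives a 1.7-fold higher number from compound 2 to compound 3 (0.23 log units; within the scatter). It therefore removes the ring carbonyl and replaces the methyl on the ring nitrogen with an ethyl in a single step, and on these data the half-life cannot be said to differ between the two groups. No available evidence bears on what lies behind this result.

The two parts of the change remain unseparated, and a 1-methylpiperidin-4-yl or 1-ethyl-2-oxopiperidin-4-yl group on the core of compound 2 would be needed to read the ring carbonyl and the longer nitrogen substituent one at a time. On these data alone, it also remains open whether the half-life would stay within the scatter with an unsubstituted piperidin-4-yl, a morpholine or a longer chain on the ring nitrogen at this aromatic carbon.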